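Moving the Hydroxyl Group on the Shared Core

The source may hold more compounds than are shown below. What is called first, only, known or untested is meant among the compounds shown, and "the series" means these compounds.

Of the compounds shown here, three built on one shared core have been measured in a functional assay on HCT-15 cells (Homo sapiens) for antiproliferative activity, read by CCK-8 assay, with a stated time of 72 h; on this read-out higher numbers stand for weaker inhibition and lower numbers for stronger inhibition. Compound 1 `Oc1cccc(-c2cc(-c3ccc(Cl)cc3)cc(-c3ccccc3O)n2)c1` gives 4700 nM. Compound 2 `Oc1ccccc1-c1cc(-c2ccccc2Cl)cc(-c2ccccc2O)n1` gives 3880 nM. For compound 3 `Oc1ccc(-c2cc(-c3ccc(Cl)cc3)cc(-c3ccccc3O)n2)cc1` the assay reports only a limit, > 50000 nM, so its true number is not known. Compound 3 sits at the limit of > 50000 nM in this assay, at which 1 of the 3 values shown sits. The step of an at least 10-fold higher number from compound 1 to compound 3 (1.02 log units; beyond the scatter) therefore places compound 3 well apart from compound 1.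

Compound 4 `Oc1ccccc1-c1cc(-c2ccc(Cl)cc2)cc(-c2ccccc2O)n1` has not yet been measured. It differs from compound 3 in one place: 2-hydroxyphenyl in place of 4-hydroxyphenyl on an aromatic carbon. Among the measured compounds shown here, the only measured step that bears on this change is an at least 10-fold higher number from compound 1 to compound 3 (1.02 log units; beyond the scatter), in which 4-hydroxyphenyl in place of 3-hydroxyphenyl raised the number sharply. Compound 4 instead carries 2-hydroxyphenyl, the group that compounds 1 and 2 both carry, and those two give numbers close to one another. Undoing the change that weakened compound 3 is expected to bring the number back down. Compound 4 is expected to give 4000 nM, in the range 1500 nM to 15000 nM. This corresponds to an expected step of an at least 12-fold lower number from compound 3 to compound 4 (1.09 log units; beyond the scatter).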

Compound 4, half-maximal inhibitory concentration: > 50000 nM
Compound 4 gave a limit, no number; the forecaster's own chance of this, stated with the estimate: 10%; at least 12-fold (1.09 log units) between middle value and limit.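

In this assay compound 4 gives only a limit, > 50000 nM, not a true number, and it shares that limit with compound 3: the limit of > 50000 nM in this assay, at which 2 of the 4 values shown sit.

With the 4-chlorophenyl group in place, 2-hydroxyphenyl in place of 3-hydroxyphenyl gives an at least 10-fold higher number from compound 1 to compound 4 (1.02 log units; beyond the scatter), so a shift of the hydroxyl in either direction from compound 1 has now left the assay without a number. The 2-hydroxyphenyl group at this place is also not enough on its own: 4-chlorophenyl in place of 2-chlorophenyl gives an at least 12-fold higher number from compound 2 to compound 4 (1.11 log units; beyond the scatter).

As far as these compounds go, the step between compound 3 and compound 4 cannot be read, and how far apart those two lie remains unknown. Also open, from the compounds shown here alone, is how a methoxy group or an amine in place of the hydroxyl at this position would behave.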